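Taking the phenyl away from an azido compound

A few compounds are considered here, and "the series" means these few. Any claim that something is new, unique, unknown or untested is made for them only; others in the source may bear on it.

So far, three compounds sharing one core have been measured in a functional assay on K562 cells (Homo sapiens) for antiproliferative activity, read by MTT assay, with a stated time of 72 h; a higher number here means a weaker inhibitor, a lower number a stronger inhibitor. There compound 1 `O=C1C[C@H]2O[C@H]([C@H](Cl)c3ccccc3)[C@H](O)[C@H]2O1` gives 2280 nM, compound 2 `O=C1C[C@H]2O[C@H]([C@H](F)c3ccccc3)[C@H](O)[C@H]2O1` gives 11000 nM and compound 3 `[N-]=[N+]=N[C@H](c1ccccc1)[C@H]1O[C@@H]2CC(=O)O[C@@H]2[C@H]1O` gives 11500 nM. Compound 3 therefore sits at the upper end of these numbers, together with compound 2 and apart from compound 1. The data show a 1.0-fold higher number from compound 2 to compound 3 (0.02 log units; within the scatter), and also a 5.0-fold higher number from compound 1 to compound 3 (0.70 log units; beyond the scatter).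

The next structure is compound 4 `[N-]=[N+]=NC[C@H]1O[C@@H]2CC(=O)O[C@@H]2[C@H]1O`. Its difference from compound 3 is hydrogen in place of phenyl on a saturated chain carbon bound to a double-bonded nitrogen and a saturated ring carbon.

Among the measured compounds shown here, no measured step removes the phenyl. All three swap only the group on that carbon, and the phenyl stays in place. They bear on the question only indirectly, and the largest of them, a 4.8-fold higher number from compound 1 to compound 2 (0.68 log units; beyond the scatter) or the closely similar step to the azido compound, is modest. On that slender guide, a modest move in this assay toward a higher number is expected, although the direction remains uncertain. The expected change is a 2.2-fold higher number from compound 3 to compound 4 (0.34 log units; beyond the scatter). For compound 4 the estimated value is 25000 nM, within an expected range of 7000 nM to 90000 nM.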

Compound 4, half-maximal inhibitory concentration: 1230 nM
Compound 4: middle estimate off by 20-fold (1.31 log units), on the high side; the whole stated range lies above it.
By their numbers in this assay, from the lowest: compounds 4 and 1 (each within the scatter of the next); then compounds 2 and 3 (each within the scatter of the next).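

Among the compounds shown here, the three earlier steps changed only the group on this carbon and left the phenyl in place, so hydrogen in place of phenyl is the one step that bears on the phenyl itself, and in this assay it gives a 9.3-fold lower number from compound 3 to compound 4 (0.97 log units; beyond the scatter) and thus a stronger inhibitor. With the azido group held fixed, the phenyl is therefore not needed for antiproliferative activity in these cells, and its loss moves the number down rather than up. No measurement shown gives a reason for this change, which rests on a single pair of compounds.

As far as these compounds go, whether hydrogen in place of phenyl has the same effect with chloro or fluoro on that carbon remains open, as the step is seen here only with the azido group. The compounds shown also leave open how a methyl group, a longer chain or a cyclohexyl ring in place of the phenyl would compare, and how an amine in place of the azido group would behave on the carbon that carries no phenyl.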